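The source may hold more compounds than are shown below. What is called first, only, known or untested is meant among the compounds shown, and "the series" means these compounds.

Of the compounds shown here, three have been measured in a functional assay on A549 cells (Homo sapiens) for antiproliferative activity, read by MTT assay, with a stated time of 48 h, in the presence of a further agent that is not named here; a higher number here means a weaker inhibitor of growth, a lower number a stronger inhibitor of growth. Compound 1 `O=C(NOCc1ccccc1)c1cn(-c2ccccc2)nc1-c1ccccc1` gives 5000 nM. Compound 2 `COc1ccc(-c2nn(-c3ccccc3)cc2C(=O)NOCc2ccccc2)cc1` gives 1940 nM, and compound 3 `COc1ccc(-c2nn(-c3ccccc3)cc2C(=O)NOCc2ccc(Cl)cc2Cl)cc1` gives 3830 nM. Among these three numbers compound 2 stands lowest: the step of a 2.6-fold lower number from compound 1 to compound 2 (0.41 log units; beyond the scatter) is a modest change beyond the scatter, while the step of a 2.0-fold higher number from compound 2 to compound 3 (0.30 log units; within the scatter) is too small to be told apart from repeat measurement.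

Compound 4 `O=C(NOCc1ccccc1)c1cn(-c2ccccc2)nc1-c1ccc(F)cc1` has not been measured. It differs from compound 2 in one place: fluoro in place of methoxy on an aromatic carbon. Within the data shown here, the only measured step that touches this position is the one from compound 1 to compound 2, where methoxy in place of hydrogen gave a modest improvement. Compound 4 removes that methoxy again, but replaces it with fluoro rather than hydrogen, and nothing measured here shows what fluoro does at this position. A small move back toward the number of compound 1 seems the most reasonable expectation, but one that may stay within the scatter. Compound 4 is therefore expected to give about 3000 nM in this assay, with a likely range from 1500 nM to 6500 nM. The step that this estimate implies is expected to be a 1.5-fold higher number from compound 2 to compound 4 (0.19 log units; within the scatter).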

Compound 4, concentration for 50% growth inhibition: 10400 nM
Estimate against measurement, compound 4: 3.5-fold (0.54 log units) below; measured number outside the range, above it.
By their numbers in this assay, from the lowest: compounds 2, 3 and 1 (each within the scatter of the next, the first and the last beyond it); then compound 4.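

In this assay, the three groups at this place on the aromatic ring can now be set in order, and fluoro does not fall between hydrogen and methoxy. Changing 4-methoxyphenyl to 4-fluorophenyl gives a 5.4-fold higher number from compound 2 to compound 4 (0.73 log units; beyond the scatter), so the change goes past the hydrogen compound rather than merely undoing the gain from methoxy, and a 2.1-fold higher number from compound 1 to compound 4 (0.32 log units; beyond the scatter) confirms that fluoro lies on the far side of hydrogen. Nothing available here bears on why fluoro and methoxy differ in this way.

On these data alone, it remains open whether an ethoxy group, a hydroxyl or an amine at this place would give a number nearer that of compound 2 or that of compound 4. As far as these compounds go, it is also open whether the same order of groups would hold alongside the 2,4-dichlorophenyl group of compound 3.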